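Adding a thiophene ring to compound 1

The source may report more compounds than this note shows. Statements on the series, on what has been measured and on what is new or still open speak of the compounds shown alone.

Compound 1 `NCCCc1ccc(-c2ccc(-c3cccs3)s2)s1` gives 18900 nM
Compound 2 `BrCCCCc1ccc(-c2ccc(-c3cccs3)s2)s1` gives 23800 nM

Within the data shown here, in an ADME assay on MDCK cells (Canis lupus familiaris) for cytotoxicity, read by MTT assay, with a stated time of 2 days (a higher number here means that more compound is tolerated, a lower number that less compound is tolerated), these two numbers sit together, with a 1.3-fold higher number from compound 1 to compound 2 (0.10 log units; within the scatter) as the only measured step. That step changed the chain and nothing else. Among the measured compounds shown here, compound 3 `NCCCc1ccc(-c2ccc(-c3ccc(-c4cccs4)s3)s2)s1` differs from compound 1 by thiophen-2-yl in place of hydrogen on an aromatic carbon and no measured compound shows a change at that place. For the measured compounds named here, the one step therefore gives little guidance, and with nothing pointing either way, no shift beyond the scatter is expected in this assay here. The expected change is a 1.1-fold lower number from compound 1 to compound 3 (0.05 log units; within the scatter) as a best guess. For compound 3 the estimated value is 17000 nM with an expected range of 6000 nM to 50000 nM as its limits of uncertainty.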

Compound 3, half-maximal cytotoxic concentration: > 200000 nM
Compound 3: only a limit was reported (the forecaster's own chance of this, stated with the estimate: 15%); middle value at least 11-fold (1.07 log units) away from the limit.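

In this assay, thiophen-2-yl in place of hydrogen on an aromatic carbon, next to the ring sulfur, gives an at least 10-fold higher number from compound 1 to compound 3 (1.02 log units; beyond the scatter). This makes the position the first place shown where a single change moves the number beyond the scatter, which the chain change in a 1.3-fold higher number from compound 1 to compound 2 (0.10 log units; within the scatter) did not do. Compound 3 gives > 200000 nM, which is a limit of the assay and not a number: the limit of > 200000 nM in this assay, at which 1 of the 3 values shown sits.

On these data alone, whether a smaller group at this position, such as methyl or chlorine, or a phenyl ring in place of thiophen-2-yl, would shift the number as far remains open. So does whether the same added ring would act alike on the chain of compound 2.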